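The source may report more compounds than this note shows. Statements on the series, on what has been measured and on what is new or still open speak of the compounds shown alone.

The three measured compounds and their numbers:

Compound 1, `CC[C@H]1CN(c2ncc(C(N)=O)nc2C)CCN1C1CCN(C(=O)c2ccc(Cl)nc2N)CC1`, gives 4 nM in an in vitro assay on BaF3 cells for displacement of a labelled ligand from C-X-C chemokine receptor type 3 (Homo sapiens); a higher number here means a weaker inhibitor, a lower number a stronger inhibitor.
Compound 2, `CC[C@H]1CN(c2ncc(C(N)=O)nc2C)CCN1C1CCN(C(=O)c2ccc(Cl)cc2)CC1`, gives 18 nM in this assay.
Compound 3, `CC[C@H]1CN(c2ncc(C(=O)NC)nc2C)CCN1C1CCN(C(=O)c2ccc(Cl)cc2)CC1`, gives 3.6 nM in this assay.

Among these three, compound 2 carries the highest number and is thus the weakest inhibitor of the set. Its nearer neighbour is compound 1, separated by a 4.5-fold higher number from compound 1 to compound 2 (0.65 log units; beyond the scatter); compound 3 lies furthest off, reached by a 5.0-fold lower number from compound 2 to compound 3 (0.70 log units; beyond the scatter). Both of these steps are modest and both exceed the scatter.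

Compound 4, `CC[C@H]1CN(c2ncc(C(N)=O)nc2C)[C@H](C)CN1C1CCN(C(=O)c2ccc(Cl)cc2)CC1`, has not yet been measured. It differs from compound 2 in a single place: methyl in place of hydrogen on a saturated ring carbon. Neither measured step bears on this change. Among the measured compounds shown here, the step from compound 1 to compound 2 exchanges the aryl group on the carbonyl carbon, and the step from compound 2 to compound 3 adds a methyl on an amide-type nitrogen; nothing among the measured compounds touches a saturated ring carbon of the shared core. The author therefore expects for compound 4 a step that stays within the scatter, with no direction favoured, namely a 1.2-fold lower number from compound 2 to compound 4 (0.08 log units; within the scatter). Compound 4 is estimated at 15 nM in this assay, expected to fall between 5 nM and 50 nM.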

Compound 4, half-maximal inhibitory concentration: 5.4 nM
The estimate for compound 4 lay 2.8-fold (0.44 log units) above the measured number, within the range that was stated.
By their numbers in this assay, from the lowest: compounds 3, 1 and 4 (each within the scatter of the next); then compound 2.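

In this assay, among the compounds shown here, a single methyl on a saturated ring carbon, next to the ring atom that bears a 5-carbamoyl-3-methylpyrazin-2-yl group, produces a 3.3-fold lower number from compound 2 to compound 4 (0.52 log units; beyond the scatter), which is the first measured change at a saturated ring carbon of the shared core and shows that this position responds beyond the scatter. The added methyl brings only one heavy atom, yet its step is of modest size, as is the step for the methyl on the amide-type nitrogen, a 5.0-fold lower number from compound 2 to compound 3 (0.70 log units; beyond the scatter), so a methyl lowers the number of compound 2 at each of these two different places. The compounds shown offer no measurement that accounts for this change.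

On these data alone, it remains open whether the opposite configuration at this ring carbon, or an ethyl or hydroxymethyl group in place of the methyl, would lower the number to the same extent. Also open, as far as these compounds go, is how this ring methyl would behave in a single compound alongside the methyl on the amide-type nitrogen, or alongside the 2-amino-6-chloropyridin-3-yl group on the carbonyl carbon.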